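Piperazine methyl and cyanophenyl changes on a shared core

A few compounds are considered here, and "the series" means these few. Any claim that something is new, unique, unknown or untested is made for them only; others in the source may bear on it.

Measured so far, as antiproliferative half-maximal inhibitory concentration:
- compound 1 `COc1cc2c(Nc3ccc(C#N)cc3)ncnc2cc1OCCCN1CCN(C)CC1`: 48800 nM
- compound 2 `CCN1CCN(CCCOc2cc3ncnc(Nc4ccc(C#N)cc4)c3cc2OC)CC1`: 16000 nM
- compound 3 `COc1cc2c(Nc3ccccc3C#N)ncnc2cc1OCCCN1CCN(C)CC1`: 23400 nM

All three numbers come from a functional assay on A549 cells (Homo sapiens) for antiproliferative activity, read by MTT assay, with a stated time of 72 h; a higher number here means a weaker inhibitor, a lower number a stronger inhibitor. Compound 4 `CCN1CCN(CCCOc2cc3ncnc(Nc4ccccc4C#N)c3cc2OC)CC1` has not yet been measured in this assay.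

Compound 4 is built from compound 3 by one change, (methyl in place of hydrogen on a saturated chain carbon bound to an amine nitrogen in a ring). The same change has already been run once, from compound 1 to compound 2, where it gave a 3.1-fold lower number from compound 1 to compound 2 (0.48 log units; beyond the scatter). The two places are described in the same words, so this is the same change on two different cores. The cores differ by 2-cyanophenyl in place of 4-cyanophenyl on a nitrogen on an aromatic ring; on its own that difference gave a 2.1-fold lower number from compound 1 to compound 3 (0.32 log units; beyond the scatter).

Compound 3 sits close to compound 2, and the two values lie within the scatter of each other, so no order between them is claimed.

For the measured compounds named here, with only one earlier instance of the change, the expectation rests on that step alone: a step of about the same size is expected from compound 3 to compound 4, that is a 3.1-fold lower number from compound 3 to compound 4 (0.49 log units; beyond the scatter), because compound 1 to compound 2 gave a 3.1-fold lower number from compound 1 to compound 2 (0.48 log units; beyond the scatter). On that basis compound 4 is estimated at 7500 nM in this assay. Going by the values given here, the range expected for compound 4 runs from 3000 nM to 20000 nM, wide enough to allow for the single precedent and for the changed core.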

Compound 4, half-maximal inhibitory concentration: 6910 nM
Estimate against measurement, compound 4: 1.1-fold (0.04 log units) above; the range from low to high includes it.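

In this assay, going from 4-methylpiperazin-1-yl to 4-ethylpiperazin-1-yl gives a 3.4-fold lower number from compound 3 to compound 4 (0.53 log units; beyond the scatter), and this step carries over from the core with the 4-cyanophenyl group to the core with the 2-cyanophenyl group with no detectable change in size: the same change on two cores in this assay, a 3.1-fold lower number (0.48 log units; beyond the scatter) from compound 1 to compound 2 and a 3.4-fold lower number (0.53 log units; beyond the scatter) from compound 3 to compound 4, 1.1-fold (0.05 log units) apart, within the scatter of two such steps Read the other way, 2-cyanophenyl in place of 4-cyanophenyl on the 4-ethylpiperazin-1-yl side gives a 2.3-fold lower number from compound 2 to compound 4 (0.36 log units; beyond the scatter), which agrees just as closely with the same swap on the 4-methylpiperazin-1-yl side: the same change on two cores in this assay, a 2.1-fold lower number (0.32 log units; beyond the scatter) from compound 1 to compound 3 and a 2.3-fold lower number (0.36 log units; beyond the scatter) from compound 2 to compound 4, 1.1-fold (0.05 log units) apart, within the scatter of two such steps The two changes therefore behave as independent and additive across these four compounds, but the four form a single closed square, so the two agreements are one observation seen from two sides, and they show nothing about other cores or about the reason for either step.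

The compounds shown leave open whether the gain continues with a larger group on the piperazine nitrogen, such as propyl or 2-hydroxyethyl, or stops at ethyl. They also leave open whether the additivity holds when the nitrile on the phenyl ring gives way to another group, such as chloro or methoxy.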